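A few compounds are considered here, and "the series" means these few. Any claim that something is new, unique, unknown or untested is made for them only; others in the source may bear on it.

Compound 1 `N#CC1=C(NCC(=O)O)N(c2ccccc2)C(=O)N2CCCCC(N3CCCC3)C12` and compound 2 `N#CC1=C(/N=C/c2ccccc2)N(c2ccccc2)C(=O)N2CCCCC(N3CCCC3)C12` share one core. In a functional assay on the whole organism (strain albino) for inhibition, with Rattus norvegicus as the target, read by paw edema, with a stated time of 1 h, at a dose of 20 mmol/kg by the intraperitoneal route (a higher number here means more inhibition at the dose given (going by the name of the read-out), a lower number less inhibition), compound 1 gives 67.2%, while compound 2 gives 46.5%, the lower of the two numbers; the change between them is a number 20.7 percentage points lower from compound 1 to compound 2 (beyond the scatter). Compound 3 `N#CC1=C(NC(=O)c2ccccc2O)N(c2ccccc2)C(=O)N2CCCCC(N3CCCC3)C12` differs from compound 2 by a group of 10 heavy atoms (7 carbon, 1 nitrogen, 2 oxygen; one six-membered aromatic ring of carbon only) in place of a group of 8 heavy atoms (7 carbon, 1 nitrogen; one six-membered aromatic ring of carbon only), on a double-bonded ring carbon. Among the compounds with values here, only that one measured step bears on this change, and it reports a modest drop when the group bearing hydrogen-bond donors was lost; the entering group restores such donors, so a small step upward, near the scatter, is expected, a number 8.5 percentage points higher from compound 2 to compound 3 (within the scatter). Compound 3 is therefore estimated at 55%, within 35% to 75%.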

Compound 3, a percentage reported as inhibition, in the whole organism at one dose (the size of the read-out at that dose, not a potency): 44.7%
Compound 3: the middle estimate sits 10.3 percentage points above what was measured; measured number inside the range.
By their numbers in this assay, from the lowest: compounds 3 and 2 (each within the scatter of the next); then compound 1.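

Hydrogen-bond donors, absent from the group that leaves and present in ((2-hydroxyphenyl)carbonyl)amino, did not separate the two compounds in this assay, with a number 1.8 percentage points lower from compound 2 to compound 3 (within the scatter). Placing (2-hydroxyphenyl)carbonyl instead of carboxymethyl on the amine nitrogen gives a number 22.5 percentage points lower from compound 1 to compound 3 (beyond the scatter), so among these three compounds, both groups carrying a six-membered aromatic ring sit under the carboxymethyl compound. No available evidence explains these numbers.

Going by these compounds, it remains open whether the carboxylic acid itself matters or only the short chain carrying it. The methyl ester of compound 1, or a longer carboxyethyl chain, would test this.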